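Piperazine in Place of Piperidine: Cytotoxicity Expected Unchanged

This account rests on a few compounds, and the source may have more. Where it says the series, first, only, none or still open, it means among the compounds named here.

Three measured compounds share one core and differ only in the group attached at one position of it. Compound 1 `CC(C)(C)[Si](CCc1c(OCc2c(Cl)cccc2Cl)nc2ccc(Cl)cc2c1-c1ccccc1Cl)(c1ccccc1)c1ccccc1` carries a (2,6-dichlorobenzyl)oxy group there, compound 2 `CC(C)(C)[Si](CCc1c(OS(=O)(=O)C(F)(F)F)nc2ccc(Cl)cc2c1-c1ccccc1Cl)(c1ccccc1)c1ccccc1` a ((trifluoromethyl)sulfonyl)oxy group, and compound 3 `CC(C)(C)[Si](CCc1c(N2CCCCC2)nc2ccc(Cl)cc2c1-c1ccccc1Cl)(c1ccccc1)c1ccccc1` a piperidin-1-yl group. In an ADME assay on HepG2 2.2.15 cells (Homo sapiens) for cytotoxicity (a lower number here means that less compound is tolerated, a higher number that more compound is tolerated), compound 1 reaches only a limit, > 1020000 nM. Compound 2 in this assay likewise gives only a limit, > 1560000 nM. Compound 3 in this assay also stops at a limit, > 968000 nM. The steps a step that the two limits leave unreadable from compound 1 to compound 2, a step that the two limits leave unreadable from compound 1 to compound 3 and a step that the two limits leave unreadable from compound 2 to compound 3 therefore cannot be sized, since every end is a limit of > 1020000 nM in this assay, at which 1 of the 3 values shown sits, the limit of > 1560000 nM in this assay, at which 1 of the 3 values shown sits (the limit of > 968000 nM in this assay, at which 1 of the 3 values shown sits). Compound 3 thus stands where the other two stand: at a limit, with no number to compare.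

Compound 4 `CC(C)(C)[Si](CCc1c(N2CCNCC2)nc2ccc(Cl)cc2c1-c1ccccc1Cl)(c1ccccc1)c1ccccc1` is the next step from compound 3: piperazin-1-yl in place of piperidin-1-yl on an aromatic carbon. Among the measured compounds shown here, no measured step gives a readable size, so none bears on this change beyond showing that all three variations at this position were tolerated up to their limits. The expected step that the limit leaves unreadable from compound 3 to compound 4 is accordingly none beyond the scatter, most likely ending again at a limit. Compound 4 is estimated at 1000000 nM, with a range from 300000 nM to 2000000 nM.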

Compound 4, half-maximal cytotoxic concentration: < 18800 nM
Compound 4 ended at the assay's limit (the forecaster's own chance of this, stated with the estimate: 80%); at least 53-fold (1.72 log units) between middle value and limit.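

In this assay, this position turns out not to be indifferent: the three earlier groups gave no readable difference, whereas piperazin-1-yl gives an at least 51-fold lower number from compound 3 to compound 4 (1.71 log units; beyond the scatter). The change is small on paper, since the ring keeps its size and one ring carbon gives way to a nitrogen that brings a hydrogen-bond donor, yet it separates compound 4 from the piperidin-1-yl compound by a wide margin. The two other groups at this position point the same way, with an at least 82-fold lower number from compound 2 to compound 4 (1.91 log units; beyond the scatter) and an at least 54-fold lower number from compound 1 to compound 4 (1.73 log units; beyond the scatter), and since each of these steps runs between two limits, each gives only a minimum size, though all three lie beyond the scatter.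

From the compounds shown here alone, compound 4 gives only a limit, < 18800 nM, so how little of it is actually tolerated stays open. Also open, going by these compounds, is which feature of the piperazin-1-yl ring matters: a morpholin-4-yl ring, which has oxygen in place of the second nitrogen, or a 4-methylpiperazin-1-yl ring, which carries a methyl group on that nitrogen, could help to separate the role of the nitrogen from that of its hydrogen.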